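The compounds below may be only part of what the source reports. "The series", "measured", "known", "first", "only" and "open" are said of these compounds alone.

Measured compounds:
compound 1, `CCNS(=O)(=O)Cc1noc2ccccc12`, 39 mg/kg
compound 2, `CNS(=O)(=O)Cc1noc2ccc(F)cc12`, 35 mg/kg

Among the measured compounds shown here, in a functional assay on the whole organism (strain STD-dd) with Mus musculus as the target, in the maximal electroshock model, with a stated time of 2 h (a higher number here means that more compound is needed for the effect, a lower number that less compound is needed), compound 2 gives the lowest of the two numbers so far, but compound 1 sits within the scatter of it, so the two are not distinguishable in this assay. For the measured compounds named here, compound 1 and compound 2 differ in two places at once, and no single step between measured compounds is available; the two values only show that both changes together leave the number where it was.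

Compound 3, `CCNS(=O)(=O)Cc1noc2ccc(F)cc12`, is the unmeasured member. It differs from compound 2 by methyl in place of hydrogen on a saturated chain carbon bound to a sulfonamide nitrogen. Nothing measured here speaks to this change on its own, so no step beyond the scatter is expected in either direction, and the step from compound 2 to compound 3 is estimated as no change at the digits printed from compound 2 to compound 3 (within the scatter). Compound 3 is expected to give about 35 mg/kg, with a range from 18 mg/kg to 70 mg/kg.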

Compound 3, dose for half-maximal effect: 32 mg/kg
For compound 3 the middle estimate is 1.1-fold (0.04 log units) above the measured one; measured number inside the range.
By their numbers in this assay, from the lowest: compounds 3, 2 and 1 (each within the scatter of the next).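

Among the compounds shown here, compound 3 supplies the first single-place steps. In this assay, methyl in place of hydrogen on a saturated chain carbon bound to a sulfonamide nitrogen gives a 1.1-fold lower number from compound 2 to compound 3 (0.04 log units; within the scatter), and fluoro in place of hydrogen on an aromatic carbon gives a 1.2-fold lower number from compound 1 to compound 3 (0.09 log units; within the scatter), so neither change taken alone separates the compounds, which the two-place comparison of compound 1 and compound 2 could not show. No measurement at hand gives a reason for either step.

Still open, on these data alone, is whether a longer chain such as propyl in place of ethyl moves the number beyond the scatter. Equally open, as far as these compounds go, is whether chloro or methoxy in place of fluoro does so.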